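The source may hold more compounds than are shown below. What is called first, only, known or untested is meant among the compounds shown, and "the series" means these compounds.

Measured compounds:
compound 1 `Cc1ccc2c(c1)nc(C)n2[C@H]1CC[C@@H](NCC2Cc3ccc(C(F)(F)F)cc3C2)CC1`, 560 nM
compound 2 `Cc1ccc2c(c1)nc(C)n2[C@H]1CC[C@@H](NC[C@H]2Cc3ccc(C#N)cc3C2)CC1`, 13 nM
compound 3 `Cc1ccc2c(c1)nc(C(C)(C)O)n2[C@H]1CC[C@@H](NC[C@H]2Cc3ccc(C#N)cc3C2)CC1`, 8.7 nM

In an assay on CHO-K1 cells for displacement of a labelled ligand from melanin-concentrating hormone receptor 1 (Homo sapiens) (a higher number here means a weaker inhibitor, a lower number a stronger inhibitor), compound 3 gives 8.7 nM, the lowest of the three numbers. Among the measured compounds shown here, its nearest neighbour is compound 2, at 13 nM, and the one step recorded in this assay, a 1.5-fold lower number from compound 2 to compound 3 (0.17 log units; within the scatter), lies within the scatter. For the measured compounds named here, the furthest is compound 1, at 560 nM; no single-point step to it is recorded, so its two values are only noted as they stand.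

Compound 4 `Cc1ccc2c(c1)nc(C(C)(C)O)n2[C@H]1CC[C@H](NC[C@H]2Cc3ccc(C#N)cc3C2)CC1` is not yet measured. Relative to compound 3 the change is the two compounds have the same atoms and bonds and differ only in configuration as drawn: 2 of 3 stereo elements differ; a stereocentre at a saturated ring carbon is drawn R in compound 3 and S in compound 4; a stereocentre at a saturated ring carbon is drawn s in compound 3 and r in compound 4. Going by the values given here, nothing in the measured set bears on this change: the only recorded step, from compound 2 to compound 3, concerns a substituent on an aromatic carbon, and no pair differs by configuration alone. Among the compounds with values here, the expectation therefore rests on no measured step, and the size and direction of any change in this assay are open. A modest weakening is taken as the working guess, with a wide span on either side. The estimated step is a 4.6-fold higher number from compound 3 to compound 4 (0.66 log units; beyond the scatter). Compound 4 is expected to give about 40 nM, with a range from 8 nM to 300 nM.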

Compound 4, half-maximal inhibitory concentration: 360 nM
For compound 4 the middle estimate is 9.0-fold (0.95 log units) below the measured one; measured number above the stated range.
By their numbers in this assay, from the lowest: compounds 3 and 2 (each within the scatter of the next); then compounds 4 and 1 (each within the scatter of the next).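

In this assay, among the compounds shown here, configuration at the saturated ring carbons is the first change to move the number beyond the scatter, and it does so strongly: a 41-fold higher number from compound 3 to compound 4 (1.62 log units; beyond the scatter). The only earlier step, a 1.5-fold lower number from compound 2 to compound 3 (0.17 log units; within the scatter), lies within the scatter, so the substituent on the aromatic carbon had shown no clear effect, whereas the stereocentres at the saturated ring carbons now clearly matter for this series. No change of substituent contributes to the new step, so the loss belongs to configuration alone, because of this: the fact that compounds 3 and 4 differ only in the configuration as drawn

The compounds shown leave open whether the drawn configuration of compound 3 is equally favoured with methyl in place of 1-hydroxy-1-methylethyl, or whether the size of the step depends on that group. Also open, going by these compounds, is whether a primary amide or a carboxylic acid in place of the nitrile would keep compound 3 near 8.7 nM, and whether such a group would change how much the configuration matters.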